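A few compounds are considered here, and "the series" means these few. Any claim that something is new, unique, unknown or untested is made for them only; others in the source may bear on it.

Measured compounds:
compound 1 `COc1cc2c(cc1OC)C(CC(=O)O)CC2`: 24%
compound 2 `COc1cc2c(cc1OC)C(CC(=O)NC(C)C)CC2`: 37%
compound 3 `COc1cc2c(cc1OC)C(CC(=O)NC(C)(C)C)CC2`: 32%

In a functional assay on the whole organism (strain Wistar) for inhibition, with Rattus norvegicus as the target, read by paw edema, with stated times of 60 min and 2 h, at a dose of 100 mg/kg by the oral route (a higher number here means more inhibition at the dose given (going by the name of the read-out), a lower number less inhibition), compound 2 gives 37%, the highest of the three numbers. Compound 3 stands close by with 32% and the step of a number 5 percentage points lower from compound 2 to compound 3 (within the scatter) lies within the scatter, so no order between compound 2 and compound 3 can be read. Compound 1 with 24% is the furthest away, the step of a number 13 percentage points higher from compound 1 to compound 2 (beyond the scatter) being beyond the scatter.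

Compound 4 `COc1cc2c(cc1OC)C(CC(=O)N1CCCC1)CC2` is not yet measured. Its change from compound 2 is pyrrolidin-1-yl in place of isopropylamino on a carbonyl carbon. Among the compounds with values here, the steps that bear on it are the two amide steps from the acid, a number 13 percentage points higher from compound 1 to compound 2 (beyond the scatter) and a number 8 percentage points higher from compound 1 to compound 3 (within the scatter), and the step between the two amides, a number 5 percentage points lower from compound 2 to compound 3 (within the scatter). The series holds no amide without an amide hydrogen, so nothing measured directly covers this change. The two amides differ from each other only within the scatter, and a similar small or null step is expected here, a number 4 percentage points lower from compound 2 to compound 4 (within the scatter). Compound 4 is estimated at 33%, with a range of 20% to 46%.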

Compound 4, a percentage reported as inhibition, in the whole organism at one dose (the size of the read-out at that dose, not a potency): 20%
The estimate for compound 4 lay 13 percentage points above the measured number; low and high end bracket the measured number.
By their numbers in this assay, from the lowest: compounds 4, 1, 3 and 2 (each within the scatter of the next, the first and the last beyond it).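

In this assay, the group on the carbonyl carbon now shows a readable effect among the amides: with pyrrolidin-1-yl in place of isopropylamino the step is a number 17 percentage points lower from compound 2 to compound 4 (beyond the scatter), and with pyrrolidin-1-yl in place of (tert-butyl)amino it is a number 12 percentage points lower from compound 3 to compound 4 (beyond the scatter), whereas the two earlier amides could not be ordered. Against the acid the step is a number 4 percentage points lower from compound 1 to compound 4 (within the scatter), so replacing hydroxy with an amide does not by itself bring a gain here. No measurement on hand accounts for the loss among the amides.

The change removes the amide hydrogen and brings in a ring at the same time, and the two remain inseparable in these compounds. Cyclopentylamino, which has a ring and keeps the amide hydrogen, and diethylamino, which has no ring and no amide hydrogen, would separate them.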